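From 2-oxopropyl to isopropyl on a sulfur

This account rests on a few compounds, and the source may have more. Where it says the series, first, only, none or still open, it means among the compounds named here.

Measured in an ADME assay on MT4 cells (Homo sapiens) for cytotoxicity, read by MTT assay; on this read-out higher numbers stand for lower toxicity in this test and lower numbers for higher toxicity in this test:
Compound 1 `O=c1cc(Cc2c(F)cccc2F)nc(SCc2ccccc2)[nH]1`: > 73000 nM
Compound 2 `CC(=O)CSc1nc(Cc2c(F)cccc2F)cc(=O)[nH]1`: > 81000 nM

Compound 1 gives > 73000 nM, which is a limit and not a number. Compound 2 stands at > 81000 nM, which is also a limit. Compound 3 `CC(C)Sc1nc(Cc2c(F)cccc2F)cc(=O)[nH]1` carries isopropyl in place of 2-oxopropyl on a sulfur. Within the data shown here, the one measured step that bears on this change is a step that the two limits leave unreadable from compound 1 to compound 2, where acetyl replaces phenyl on a saturated chain carbon bound to a sulfur. That step has no readable size, so it offers none to carry over, and no step beyond the scatter is expected in this assay in either direction. The expected step is an at least 1.0-fold lower number from compound 2 to compound 3 (0.00 log units; that floor lies within the scatter). For compound 3 the estimated value is 80000 nM, with an expected range from 35000 nM to 180000 nM.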

Compound 3, half-maximal cytotoxic concentration: > 84000 nM
Compound 3: a limit, no number; the forecaster's own chance of this, stated with the estimate: 70%; at least 1.0-fold (0.02 log units) between middle value and limit.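

In this assay, among these compounds, compound 1, compound 2 and compound 3 all give limits and not numbers, so no step among them can be read. The compounds shown leave open where each true value lies, and whether 2-oxopropyl, isopropyl or benzyl on a sulfur differ at all.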